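The source may report more compounds than this note shows. Statements on the series, on what has been measured and on what is new or still open speak of the compounds shown alone.

In a functional assay (plasma) for inhibition, with Homo sapiens as the target (a lower number here means a stronger inhibitor, a higher number a weaker inhibitor), compound 1 (`CCCCC(C)(C)[C@H](O)/C=C/C1C2CCC(O2)C1C/C=C\CCCC(=O)O`) gives > 1000000 nM, which is a limit and not a number. Compound 2 (`O=C(O)CCC/C=C\CC1C2CCC(O2)C1/C=C/[C@@H](O)CCc1ccccc1`) gives > 1000000 nM, again a limit. Within the data shown here, compound 3 (`C[C@@H](c1ccc(O)cc1)[C@H](O)/C=C/C1C2CCC(O2)C1C/C=C\CCCC(=O)O`) gives 950000 nM, the only true number among the three. The measured steps offer little: the data show a step that the two limits leave unreadable from compound 1 to compound 2, then an at least 1.0-fold lower number from compound 1 to compound 3 (0.02 log units; that floor lies within the scatter), and also an at least 1.0-fold lower number from compound 2 to compound 3 (0.02 log units; that floor lies within the scatter). Compound 4 (`C[C@@H](c1ccc(O)c(I)c1)[C@H](O)/C=C/C1C2CCC(O2)C1C/C=C\CCCC(=O)O`) differs from compound 3 by one change: iodo in place of hydrogen on an aromatic carbon. Among the measured compounds shown here, no measured step covers iodo in place of hydrogen on an aromatic carbon, and both readable floors stay within the scatter. No change beyond the scatter is therefore expected, and the estimate is a 1.6-fold lower number from compound 3 to compound 4 (0.20 log units; within the scatter). The expected value for compound 4 is 600000 nM, with an estimated range of 150000 nM to 2000000 nM.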

Compound 4, half-maximal inhibitory concentration: > 1000000 nM
Compound 4 was reported as a limit; the forecaster's own chance of this, stated with the estimate: 35%; middle value at least 1.6-fold (0.22 log units) from the limit.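

In this assay, the data show an at least 1.0-fold higher number from compound 3 to compound 4 (0.02 log units; that floor lies within the scatter), so iodo ortho to the hydroxy group brings no lower number than hydrogen on this aromatic carbon. Compound 4 gives only a limit, and its steps from compound 1 and compound 2 cannot be read. Of the four compounds, only compound 3 has a true number, and the others rest at one ceiling: the limit of > 1000000 nM in this assay, at which 3 of the 4 values shown sit.

On these data alone, how far compound 4 lies past its limit stays open. So does whether chloro or an amine on this aromatic carbon would read differently from iodo or hydrogen.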